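Fluoro on an inactive pair: working notes toward compound 3

The source may report more compounds than this note shows. Statements on the series, on what has been measured and on what is new or still open speak of the compounds shown alone.

Compound 1 `Nc1ccn([C@H]2O[C@@H](CO)C=C2F)c(=O)n1` gives > 100000 nM in a functional assay on CCRF-CEM cells (Homo sapiens) for inhibition (a higher number here means a weaker inhibitor, a lower number a stronger inhibitor), which is a limit of the assay. Compound 2 `Nc1ccn([C@@H]2O[C@@H](CO)C=C2F)c(=O)n1` gives > 100000 nM in this assay, again only a limit. Common to both is the limit of > 100000 nM in this assay, at which 2 of the 2 values shown sit. Within the data shown here, the only measured step is a step that the two limits leave unreadable from compound 1 to compound 2, and behind it lies (the fact that compounds 1 and 2 differ only in the configuration as drawn). Compound 3 `Nc1nc(=O)n([C@@H]2O[C@@H](CO)C=C2F)cc1F` derives from compound 2 through (fluoro in place of hydrogen on an aromatic carbon), fluoro in place of hydrogen on an aromatic carbon. Among the measured compounds shown here, no measured step covers that change, so no clear direction is expected in this assay. The expected step is a number no higher from compound 2 to compound 3 (the limit leaves the size open). For compound 3 the estimated value is 100000 nM, with an expected range of 30000 nM to 300000 nM.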

Compound 3, half-maximal inhibitory concentration: > 100000 nM
Compound 3 ended at the assay's limit; the forecaster's own chance of this, stated with the estimate: 75%; the middle value lies on the limit itself.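

In this assay compound 3 gives > 100000 nM, only a limit, so no step can be read between compound 2 and compound 3. The compounds shown leave open whether fluoro in place of hydrogen on an aromatic carbon changes inhibition at all.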